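Dimethoxyphenyl in Place of Fluoromethylphenyl: Vero Toxicity

The compounds below may be only part of what the source reports. "The series", "measured", "known", "first", "only" and "open" are said of these compounds alone.

Compound 1 `COC(=O)c1cc(-c2cccc(NC(=O)c3ccc(/C=C/C(=O)c4cccc([N+](=O)[O-])c4)cc3)c2)on1`: in an ADME assay on Vero cells (Chlorocebus sabaeus) for cytotoxicity, read by MTT assay, with a stated time of 72 h (on this read-out lower numbers stand for higher toxicity in this test and higher numbers for lower toxicity in this test), compound 1 gives only the limit > 40 ug/mL.
Compound 2 `CCOc1ccc(C(=O)/C=C/c2ccc(C(=O)Nc3cccc(-c4cc(C(=O)OC)no4)c3)cc2)cc1`: in this assay compound 2 gives only the limit > 40 ug/mL.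
Compound 3 `COC(=O)c1cc(-c2cccc(NC(=O)c3ccc(/C=C/C(=O)c4ccc(C)c(F)c4)cc3)c2)on1`: in this assay compound 3 gives only the limit > 50 ug/mL.

Compound 3 thus stands at a limit, as do the other two measured compounds, which is what the limit of > 40 ug/mL in this assay, at which 2 of the 3 values shown sit, and the limit of > 50 ug/mL in this assay, at which 1 of the 3 values shown sits, record. The steps a step that the two limits leave unreadable from compound 1 to compound 3 and a step that the two limits leave unreadable from compound 2 to compound 3, like a step that the two limits leave unreadable from compound 1 to compound 2, therefore give no readable size. Compound 4 `COC(=O)c1cc(-c2cccc(NC(=O)c3ccc(/C=C/C(=O)c4ccc(OC)cc4OC)cc3)c2)on1` differs from compound 3 by 2,4-dimethoxyphenyl in place of 3-fluoro-4-methylphenyl on a carbonyl carbon. Going by the values given here, with no measured step readable, no step beyond the scatter is expected in this assay. Compound 4 is accordingly estimated at 50 ug/mL, within 25 ug/mL to 100 ug/mL. That estimate means an expected step of a number no higher from compound 3 to compound 4 (the limit leaves the size open), most likely reported again as a limit.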

Compound 4, half-maximal cytotoxic concentration: > 50 ug/mL
Compound 4: a limit, no number (the forecaster's own chance of this, stated with the estimate: 75%); the middle value lies on the limit itself.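

Compound 4, like compound 1, compound 2 and compound 3, gives only a limit in this assay, so none of the steps to compound 4 can be read. The compounds shown leave open where any actual half-maximal cytotoxic concentration lies, and whether these groups on the carbonyl carbon change it.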